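Chloro for trifluoromethyl on the urea aryl of compound 2

This account rests on a few compounds, and the source may have more. Where it says the series, first, only, none or still open, it means among the compounds named here.

Compound 2 `COc1cc(Cl)cc(-c2nn(-c3cccc(NC(=O)Nc4ccc(Cl)c(C(F)(F)F)c4)c3)cc2-c2ccncc2)c1` stands highest of the two numbers in hand: in a functional assay on SK-MEL-2 cells (Homo sapiens) for inhibition, read by sulforhodamine B assay, with a stated time of 48 h, tested at 0.01 uM (a lower number here means a stronger effect, a higher number a weaker effect of the compound at the concentration tested), compound 2 gives 102%, while compound 1 `O=C(Nc1cccc(-n2cc(-c3ccncc3)c(-c3cc(O)cc(Cl)c3)n2)c1)Nc1ccc(Cl)c(Cl)c1` gives 59%, a gap beyond the usual scatter. The two compounds differ in more than one place, so the gap is not assigned to any single change. Compound 3 `COc1cc(Cl)cc(-c2nn(-c3cccc(NC(=O)Nc4ccc(Cl)c(Cl)c4)c3)cc2-c2ccncc2)c1` differs from compound 2 by chloro in place of trifluoromethyl on an aromatic carbon. Going by the values given here, no single-point step of this kind is measured here. A modest downward step is expected, judged loosely against compound 1 at 59%, which carries the same 3,4-dichlorophenyl group; compound 3 is estimated at 88%, range 62% to 108%, meaning an expected step of a number 14 percentage points lower from compound 2 to compound 3 (beyond the scatter).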

Compound 3, a percentage reported as activity, at one concentration (the size of the read-out at that concentration, not a potency): 96%
For compound 3 the middle estimate is 8 percentage points below the measured one; the measured number falls inside the stated range.
By their numbers in this assay, from the lowest: compound 1; then compounds 3 and 2 (each within the scatter of the next).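

In this assay the change from trifluoromethyl to chloro on the urea aryl gives a number 6 percentage points lower from compound 2 to compound 3 (within the scatter) and so does not separate the two groups at this position. With the 3,4-dichlorophenyl urea held constant, the change on the oxygen gives a number 37 percentage points higher from compound 1 to compound 3 (beyond the scatter) and thus accounts for a large step on its own. Nothing in hand explains either step.

From the compounds shown here alone, whether the free hydroxyl gives the same step with trifluoromethyl on the urea aryl remains open. So does the effect of a nitrile at the urea position or an amine in place of the oxygen substituent.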